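A Bromo for Chloro Swap at the Ester Oxygen

This account rests on a few compounds, and the source may have more. Where it says the series, first, only, none or still open, it means among the compounds named here.

Three esters built on a shared core have been examined in an ADME assay on cells (T-cell, Mus musculus, strain BALB/c) for cytotoxicity, read by MTT assay, with a stated time of 48 h; a higher number here means that more compound is tolerated, a lower number that less compound is tolerated. Compound 1 `COC(=O)c1cc(F)ccc1OC(=O)COc1cc(O)c2c(=O)cc(-c3ccccc3)oc2c1` gives 389000 nM. Compound 2 `COC(=O)c1cc(O)ccc1OC(=O)COc1cc(O)c2c(=O)cc(-c3ccccc3)oc2c1` gives 263000 nM in this assay. Compound 3 `COC(=O)c1cccc(Cl)c1OC(=O)COc1cc(O)c2c(=O)cc(-c3ccccc3)oc2c1` gives 366000 nM in this assay. Compound 3 stands second highest of the three numbers, its nearest neighbour being compound 1; the steps of a 1.1-fold lower number from compound 1 to compound 3 (0.03 log units; within the scatter) and a 1.4-fold higher number from compound 2 to compound 3 (0.14 log units; within the scatter), like the step of a 1.5-fold lower number from compound 1 to compound 2 (0.17 log units; within the scatter), all stay within the scatter, so the three values cannot be told apart.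

Compound 4 `COC(=O)c1c(Br)cccc1OC(=O)COc1cc(O)c2c(=O)cc(-c3ccccc3)oc2c1` has not yet been measured. It differs from compound 3 as follows: a group of 11 heavy atoms (8 carbon, 2 oxygen, 1 bromine; one six-membered aromatic ring of carbon only) in place of a group of 11 heavy atoms (8 carbon, 2 oxygen, 1 chlorine; one six-membered aromatic ring of carbon only), on an oxygen next to a carbonyl group. Within the data shown here, the steps that bear on this change are the two that exchanged the whole group on the oxygen next to a carbonyl group, a 1.1-fold lower number from compound 1 to compound 3 (0.03 log units; within the scatter) and a 1.4-fold higher number from compound 2 to compound 3 (0.14 log units; within the scatter), and both lay within the scatter; exchanging one halogen for another within this group has not shifted the number in this small set. For compound 4 the step of a 1.0-fold lower number from compound 3 to compound 4 (0.02 log units; within the scatter) is therefore expected to remain within the scatter. The estimate for compound 4 in this assay is 350000 nM, with a range from 200000 nM to 600000 nM.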

Compound 4, half-maximal cytotoxic concentration: 388000 nM
Beside the measured number, compound 4's estimate is 1.1-fold (0.04 log units) below it; the range from low to high includes it.
By their numbers in this assay, from the lowest: compounds 2, 3, 4 and 1 (each within the scatter of the next).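

Among these compounds, with a group holding bromine in place of one holding chlorine on an oxygen next to a carbonyl group, this assay now shows a bromine-bearing group for the first time, and the step is a 1.1-fold higher number from compound 3 to compound 4 (0.03 log units; within the scatter). The bromine-bearing group also compares directly with the other two groups, giving a 1.5-fold higher number from compound 2 to compound 4 (0.17 log units; within the scatter) and a 1.0-fold lower number from compound 1 to compound 4 (0.00 log units; within the scatter), so all the exchanges of this group shown so far, whether the group carries fluorine, chlorine, bromine or a hydroxy group, leave the four compounds indistinguishable, and none of them goes against this. No measurement at hand accounts for this flat picture.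

The compounds shown leave open whether the picture would hold for groups of another kind on this oxygen, such as a phenyl ring carrying an amine or a carboxylic acid, or a longer chain in place of the methoxycarbonyl group. They also leave open whether a change elsewhere on the shared core, which stays the same in all four compounds, would move the number in this assay beyond the scatter.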